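The source may hold more compounds than are shown below. What is called first, only, known or untested is meant among the compounds shown, and "the series" means these compounds.

Compounds measured so far:
compound 1, `CC(=O)Nc1ccc(/C=N/Nc2nc(N)c3ncn([C@@H]4O[C@H](CO)[C@@H](O)[C@H]4O)c3n2)cc1` — > 10000 nM
compound 2, `Nc1nc(N/N=C/c2ccc[nH]2)nc2c1ncn2[C@@H]1O[C@H](CO)[C@@H](O)[C@H]1O` — 8 nM
compound 3, `Nc1nc(N/N=C/c2ccc(Cl)c(C(F)(F)F)c2)nc2c1ncn2[C@@H]1O[C@H](CO)[C@@H](O)[C@H]1O` — > 10000 nM

In an assay on CHO-K1 cells for displacement of a labelled ligand from adenosine receptor A1 (Homo sapiens), read by scintillation counting, with a stated time of 60 min (on this read-out lower numbers stand for stronger inhibition and higher numbers for weaker inhibition), compound 3 gives only a limit, > 10000 nM, and compound 1 likewise sits at a limit (the limit of > 10000 nM in this assay, at which 2 of the 3 values shown sit). Compound 2 gives 8 nM, and the step of an at least 1200-fold higher number from compound 2 to compound 3 (3.09 log units; beyond the scatter) is large, as is an at least 1200-fold lower number from compound 1 to compound 2 (3.09 log units; beyond the scatter); the step that the two limits leave unreadable from compound 1 to compound 3 cannot be read between two limits. Compound 4, `Nc1nc(N/N=C/c2ccc(C(F)(F)F)cc2)nc2c1ncn2[C@@H]1O[C@H](CO)[C@@H](O)[C@H]1O`, differs from compound 3 by 4-(trifluoromethyl)phenyl in place of 4-chloro-3-(trifluoromethyl)phenyl on a carbon with a double bond to nitrogen. Going by the values given here, no measured step compares two substituted phenyl groups with each other, so the data give no direct guide; both phenyl-bearing compounds stand at the limit. Compound 4 is therefore expected to remain near the limit, with a step that the limit leaves unreadable from compound 3 to compound 4 as the estimated step, and an estimated value of 20000 nM (range 3000 nM to 100000 nM).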

Compound 4, inhibition constant: 37 nM
Estimate against measurement, compound 4: 540-fold (2.73 log units) above; measured number outside the range, below it.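

In this assay, 4-(trifluoromethyl)phenyl in place of 4-chloro-3-(trifluoromethyl)phenyl gives an at least 270-fold lower number from compound 3 to compound 4 (2.43 log units; beyond the scatter), so a phenyl group on this carbon does not by itself hold a compound at the limit. Trifluoromethyl in place of acetamido gives an at least 270-fold lower number from compound 1 to compound 4 (2.43 log units; beyond the scatter), while 4-(trifluoromethyl)phenyl in place of 1H-pyrrol-2-yl gives only a 4.6-fold higher number from compound 2 to compound 4 (0.67 log units; beyond the scatter). The two larger steps start from compounds that stand at a limit: the limit of > 10000 nM in this assay, at which 2 of the 4 values shown sit.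

Going by these compounds, this change removes the chlorine and also alters where the trifluoromethyl group stands, so which of the two matters stays open. A 3-(trifluoromethyl)phenyl or a 4-chlorophenyl group would separate them.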